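One Small Group Swapped on a Shared Core

A few compounds are considered here, and "the series" means these few. Any claim that something is new, unique, unknown or untested is made for them only; others in the source may bear on it.

Of the compounds shown here, three sharing a core have been measured in a functional assay on HL-60 cells (Homo sapiens) for cytotoxicity, read by MTT assay, with a stated time of 3 days; on this read-out higher numbers stand for weaker inhibition and lower numbers for stronger inhibition. In this test, compound 1 (`N#Cc1c(O)nc(SCc2nc3ccccc3[nH]2)nc1-c1ccccc1`) gives 2.55 nM, compound 2 (`N#Cc1c(Nc2ccccn2)nc(SCc2nc3ccccc3[nH]2)nc1-c1ccccc1`) gives 20 nM, and compound 3 (`N#Cc1c(NNC(N)=S)nc(SCc2nc3ccccc3[nH]2)nc1-c1ccccc1`) gives 4.54 nM. Two steps show where compound 3 stands. The first is a 1.8-fold higher number from compound 1 to compound 3 (0.25 log units; within the scatter), which lies within the scatter, the ordinary spread of repeated measurements. The second is a 4.4-fold lower number from compound 2 to compound 3 (0.64 log units; beyond the scatter), which lies beyond it.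

Compound 4 (`N#Cc1c(NC(N)=O)nc(SCc2nc3ccccc3[nH]2)nc1-c1ccccc1`) keeps the shared core and differs in one group: a group of 3 heavy atoms (1 carbon, 1 nitrogen, 1 oxygen; no ring) in place of a group of 4 heavy atoms (1 carbon, 2 nitrogen, 1 sulfur; no ring), on a nitrogen on an aromatic ring. Within the data shown here, the earlier steps changed the group at this same aromatic carbon position, and they give the only guide. The ring-bearing group of compound 2 produced a modest change, a 7.8-fold higher number from compound 1 to compound 2 (0.89 log units; beyond the scatter), whereas the ring-free group of compound 3 left the number within the scatter of compound 1. Among the measured compounds shown here, the incoming carbamoyl also has no ring, but two related examples cannot establish a rule, and no measured step isolates this exact swap. The estimated step is a 1.1-fold higher number from compound 3 to compound 4 (0.04 log units; within the scatter), so no change beyond the scatter is expected in this assay. For compound 4 the estimated value is 5 nM, with an expected range from 1.5 nM to 17 nM.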

Compound 4, half-maximal inhibitory concentration: 2.9 nM
The estimate for compound 4 lay 1.7-fold (0.24 log units) above the measured number, within the range that was stated.
By their numbers in this assay, from the lowest: compounds 1, 4 and 3 (each within the scatter of the next); then compound 2.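

In this assay, carbamoyl on this nitrogen in place of the sulfur-bearing group of compound 3 gives a 1.6-fold lower number from compound 3 to compound 4 (0.19 log units; within the scatter) and so no change that can be told apart from the scatter, even though sulfur leaves and oxygen enters. The comparison with the hydroxy group gives a 1.1-fold higher number from compound 1 to compound 4 (0.06 log units; within the scatter), which means that compound 1, compound 3 and compound 4, with three different ring-free groups on this aromatic carbon, all lie within the scatter of one another. Compound 2 goes against this grouping, as the step to the carbamoyl group, a 6.9-fold lower number from compound 2 to compound 4 (0.84 log units; beyond the scatter), is beyond the scatter, and among these four compounds it alone carries a ring at this place, a link that rests on this single compound.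

Nothing shown here explains why the pyridin-2-yl compound stands apart from the other three. On these data alone, it also remains open whether a plain amine or a longer alkyl chain at this aromatic carbon would stay with the ring-free groups, and whether a phenyl ring would move the number as pyridin-2-yl does.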